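The source may report more compounds than this note shows. Statements on the series, on what has been measured and on what is new or still open speak of the compounds shown alone.

Four compounds share a long unsaturated chain that ends in a carbonyl group, and they differ at two places. Compound 1 `C=CCOC(=O)/C=C(C)/C=C/CC(C)CCCC(C)C` carries an allyloxy group on the carbonyl carbon and an isopropyl end on the chain. In a physicochemical assay for lipophilicity (on this read-out higher numbers stand for higher lipophilicity and lower numbers for lower lipophilicity), compound 1 gives 6.73. Compound 2 `C=CCOC(=O)/C=C(C)/C=C/CC(C)CCCC(C)(C)OC` differs from compound 1 by methoxy in place of hydrogen on a saturated chain carbon bound to three saturated chain carbons and the step is a number 1.20 log units lower from compound 1 to compound 2 (beyond the scatter). Compound 3 `CCNC(=O)/C=C(C)/C=C/CC(C)CCCC(C)C` differs from compound 1 in the core by ethylamino in place of allyloxy on a carbonyl carbon; in this assay compound 3 gives 5.24, while compound 2 gives 5.53, which is within the scatter of the value of compound 3.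

Compound 4 `CCNC(=O)/C=C(C)/C=C/CC(C)CCCC(C)(C)OC` has not yet been measured. It differs from compound 3 by methoxy in place of hydrogen on a saturated chain carbon bound to three saturated chain carbons, which is the same change as that from compound 1 to compound 2: the place lines agree word for word. Among the compounds with values here, that earlier change is the only example of this kind, so the expectation rests on a single pair. A step of about a number 1.19 log units lower from compound 3 to compound 4 (beyond the scatter) is expected because of a number 1.20 log units lower from compound 1 to compound 2 (beyond the scatter). Compound 4 is therefore estimated at 4.05, between 3.55 and 4.55.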

Compound 4, partition coefficient: 4.04
Compound 4: middle estimate off by 0.01 log units, on the high side; low and high end bracket the measured number.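

In this assay the methoxy change gives a number 1.20 log units lower from compound 3 to compound 4 (beyond the scatter) and so matches a number 1.20 log units lower from compound 1 to compound 2 (beyond the scatter) in size, while ethylamino in place of allyloxy on a carbonyl carbon gives a number 1.49 log units lower from compound 2 to compound 4 (beyond the scatter) and so matches a number 1.49 log units lower from compound 1 to compound 3 (beyond the scatter) in size. Across these four compounds, then, each change has the same size whichever form the other place takes, and the methoxy step carries over unchanged from the core of compound 1 to the core of compound 3. This is a single transfer between two cores in one assay, so it does not show that the step would hold on any other core, and nothing given here explains why the numbers move as they do.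

As far as these compounds go, it remains open whether a hydroxyl or an ethoxy group in place of the methoxy on that chain carbon would give a step of similar size. From the compounds shown here alone, it is also open whether the methoxy step would stay the same with a carboxylic acid or a dimethylamino group on the carbonyl carbon.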